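Trimming an Amide: From Compound 1 to Compound 3

This account rests on a few compounds, and the source may have more. Where it says the series, first, only, none or still open, it means among the compounds named here.

Compound 1, `CCN(CC)C(=O)[C@@H]1CN[C@H](C(=O)N2CCC[C@H]2C#N)C1`, has no result in an assay on the whole organism (plasma, strain Sprague-Dawley) for inhibition of Dipeptidyl peptidase 4 (Rattus norvegicus), with a stated time of 10 h, at a dose of 1 mg/kg by the oral route; a lower number here means less inhibition, a higher number more inhibition at the dose given (going by the name of the read-out): in this assay compound 1 stands as "not determined" (no result reported), so where it sits on this read-out is simply not known. A related analogue, compound 2, `CCN(C)C(=O)[C@H]1C[C@@H](C(=O)N2CCC[C@H]2C#N)N[C@H]1C`, has been measured: in this assay compound 2 gives 79%, showing that compounds of this kind can keep a large share of the enzyme blocked long after dosing. The untested compound 3, `CNC(=O)[C@@H]1CN[C@H](C(=O)N2CCC[C@H]2C#N)C1`, is reached from compound 1 by a single change: methylamino in place of diethylamino on a carbonyl carbon. Going by the values given here, no pair of measured compounds shows this change, so the size of the step in this assay cannot be read from the data; it could run either way, and a shift beyond the usual scatter is plausible but not assured. Taking the result of compound 2, 79%, as the only anchor, compound 3 is expected to give 60% in this assay, within an estimated range of 25% to 90%.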

Compound 3, a percentage reported as inhibition, in the whole organism at one dose (the size of the read-out at that dose, not a potency): 28%
Beside the measured number, compound 3's estimate is 32 percentage points above it; the range from low to high includes it.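

Going by these compounds alone, compound 1 reads "not determined" (no result reported) in this assay and compound 3 reads 28% there, so no step from compound 1 to compound 3 can be read. How methylamino in place of diethylamino shifts this read-out stays open, and no evidence shown bears on the result of compound 3.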